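Fluoro added to compound 3: clearance notes

A few compounds are considered here, and "the series" means these few. Any claim that something is new, unique, unknown or untested is made for them only; others in the source may bear on it.

In an in vitro ADME assay on microsomes from liver (Homo sapiens) for pharmacokinetics, read by LC-MS (a lower number here means slower removal, a higher number faster removal of the compound), compound 1 `Cc1nc2c(F)cccc2n1-c1ccc(C(=O)NC2CC2)s1` gives < 4 mL/min/kg as a limit and not a number. Compound 2 `Cc1nc2ccc(F)cc2n1-c1ccc(C(=O)NC2CC2)s1` gives < 4 mL/min/kg as a limit too. Compound 3 `Cc1nc2c(Cl)cccc2n1-c1ccc(C(=O)NC2CC2)s1` gives < 4 mL/min/kg as a limit as well, so its standing is known only as a bound. The evidence so far is the limit of < 4 mL/min/kg in this assay, at which 3 of the 3 values shown sit, and no ranking of the three follows from it.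

Compound 4 `Cc1nc2c(Cl)cc(F)cc2n1-c1ccc(C(=O)NC2CC2)s1` differs from compound 3 by fluoro in place of hydrogen on an aromatic carbon and thus has fluoro in place of hydrogen on an aromatic carbon, meta to a chloro group. Within the data shown here, the only measured step is a step that the two limits leave unreadable from compound 1 to compound 3 and it gives no size to carry over to this change. No step beyond the scatter is therefore expected in this assay and no direction is expected either. The estimated change is a step that the limit leaves unreadable from compound 3 to compound 4 and another limit reading is likely. Compound 4 is estimated at 3 mL/min/kg with an expected range from 2 mL/min/kg to 6 mL/min/kg as working bounds.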

Compound 4, clearance: 5 mL/min/kg
For compound 4 the middle estimate is 1.7-fold (0.22 log units) below the measured one; low and high end bracket the measured number.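

In this assay compound 4 is the only compound shown that gives a number rather than a limit, and the other three share one limit: the limit of < 4 mL/min/kg in this assay, at which 3 of the 4 values shown sit.

Fluoro in place of hydrogen, meta to a chloro group, gives an at least 1.2-fold higher number from compound 3 to compound 4 (0.09 log units; that floor lies within the scatter), and chloro in place of hydrogen gives an at least 1.2-fold higher number from compound 2 to compound 4 (0.09 log units; that floor lies within the scatter). Both steps are floors, so they show the direction of the change at these positions but not its full size, and neither fluoro nor chloro alone can be credited with it.

The step from compound 1 to compound 3 cannot be read, which leaves fluoro and chloro at that position unranked. Also open, going by these compounds, is how a methoxy group or an amine in place of the added fluoro would read in this assay.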